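Relocating the nitrogen in a ketone-linked piperidine series

This account rests on a few compounds, and the source may have more. Where it says the series, first, only, none or still open, it means among the compounds named here.

Three compounds share a core in which a butanoyl chain carries a piperidine, and they differ only at the ring carbon opposite the nitrogen. Compound 1 `COc1cc(COc2cc(N)c(Cl)cc2C(=O)CCCCN2CCC(C)CC2)cc(OC)c1` gives 8.3 in a functional assay for antagonist activity at 5-hydroxytryptamine receptor 4 (Rattus norvegicus); a higher number here means a more potent compound, by a factor of ten per unit of this negative logarithm, a lower number a less potent compound. Compound 2 `COc1cc(COc2cc(N)c(Cl)cc2C(=O)CCCCN2CCC(O)CC2)cc(OC)c1` gives 8.3 in this assay, and compound 3 `COc1cc(COc2cc(N)c(Cl)cc2C(=O)CCCCN2CCC(OC)CC2)cc(OC)c1` gives 8.4. Compound 3 holds the highest of the three numbers, yet both gaps to it are within the scatter: a number 0.10 log units higher from compound 1 to compound 3 (within the scatter), and a number 0.10 log units higher from compound 2 to compound 3 (within the scatter); likewise no change at the digits printed from compound 1 to compound 2 (within the scatter).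

Compound 4 `CCCCN1CCC(CCC(=O)c2cc(Cl)c(N)cc2OCc2cc(OC)cc(OC)c2)CC1` is not yet measured. Its change from compound 3 is 1-butylpiperidin-4-yl in place of 2-(4-methoxypiperidin-1-yl)ethyl on a saturated chain carbon, two bonds along the chain from a carbonyl carbon. Going by the values given here, none of the measured steps touches this kind of change; all three concern a single substituent on a saturated ring carbon and are within the scatter, so they say only that the distal ring position tolerates small groups. As far as these compounds go, the place of the nitrogen within the chain is untested. An expected drop is therefore a guess with wide limits: for compound 4 the value is estimated at 7.7, between 6.8 and 8.6, an expected step of a number 0.70 log units lower from compound 3 to compound 4 (beyond the scatter).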

Compound 4, negative logarithm of the antagonist equilibrium constant: 8.9
Estimate against measurement, compound 4: 1.20 log units below, outside the stated range (above it).
By their numbers in this assay, from the lowest: compounds 1, 2 and 3 (each within the scatter of the next); then compound 4.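

In this assay, going by these compounds alone, putting 1-butylpiperidin-4-yl at this place gives a number 0.50 log units higher from compound 3 to compound 4 (beyond the scatter), and the same kind of change gives a number 0.60 log units higher from compound 2 to compound 4 (beyond the scatter) and a number 0.60 log units higher from compound 1 to compound 4 (beyond the scatter), whereas the earlier steps at the distal ring carbon all stayed within the scatter. The piperidine therefore need not be joined to the chain through its nitrogen: attached through its ring carbon, and with a butyl group on the nitrogen, it gives a higher number than any of the three earlier compounds. No measured evidence is at hand to explain this rise.

Compound 4 changes the attachment of the ring and adds the butyl group on the nitrogen together, so the two contributions remain unseparated. Also open, as far as these compounds go, is how a shorter group such as methyl or a longer chain such as hexyl on that nitrogen would read.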